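The source may hold more compounds than are shown below. What is called first, only, known or untested is meant among the compounds shown, and "the series" means these compounds.

The three compounds share one core and differ mainly in the group carried on the sulfonamide nitrogen. Compound 1 `CCc1ccc(N(Cc2ccccc2)S(=O)(=O)c2ccc3c(c2)C(=O)CC(C2CCOCC2)O3)cc1` gives 4.84 in a physicochemical assay for lipophilicity, at pH 7.4; on this read-out lower numbers stand for lower lipophilicity and higher numbers for higher lipophilicity. Compound 2 `CCc1ccc(N(CC(C)C)S(=O)(=O)c2ccc3c(c2)C(=O)CC(C2CCNCC2)O3)cc1` gives 2.21 in this assay, and compound 3 `CCc1ccc(N(CC2CCC2)S(=O)(=O)c2ccc3c(c2)C(=O)CC(C2CCOCC2)O3)cc1` gives 4.1. Compound 3 thus stands second highest of the three numbers: its nearest neighbour is compound 1, which lies higher by a step that is beyond the scatter, while compound 2 lies much lower, also beyond the scatter. Within the data shown here, the one step between two compounds that differ in a single place is a number 0.74 log units lower from compound 1 to compound 3 (beyond the scatter), a modest move down.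

Compound 4 `CCc1ccc(N(C2CCC2)S(=O)(=O)c2ccc3c(c2)C(=O)CC(C2CCOCC2)O3)cc1` has not yet been measured in this assay. It differs from compound 3 in one place: cyclobutyl in place of cyclobutylmethyl on a sulfonamide nitrogen. Among the measured compounds shown here, no measured step covers exactly this change; the only step that bears on it is the one from compound 1 to compound 3, where the group on that nitrogen was altered and a modest downward move resulted. Since compound 4 carries one fewer carbon than compound 3, a small downward step in this assay is expected for compound 4, of about a number 0.40 log units lower from compound 3 to compound 4 (beyond the scatter). Compound 4 is therefore estimated at 3.7, within a range from 3.3 to 4.1.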

Compound 4, distribution coefficient: 3.78
Compound 4: middle estimate off by 0.08 log units, on the low side; the range from low to high includes it.
By their numbers in this assay, from the lowest: compound 2; then compound 4; then compound 3; then compound 1.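

In this assay, cyclobutyl in place of cyclobutylmethyl on a sulfonamide nitrogen gives a number 0.32 log units lower from compound 3 to compound 4 (beyond the scatter) as a modest step, which shows that this number responds to the loss of the chain carbon even when the four-membered ring is kept. Cyclobutyl in place of benzyl at the same place gives a number 1.06 log units lower from compound 1 to compound 4 (beyond the scatter) as a large step, whereas the earlier change on this nitrogen (a number 0.74 log units lower from compound 1 to compound 3 (beyond the scatter)) was modest. Compound 4 therefore adds a second kind of change at this position, one that alters the link between the ring and the nitrogen rather than the ring alone, and both steps lie beyond the scatter.

The compounds shown offer no measurement that explains either step.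

Going by these compounds, whether a cyclopentyl group, a longer chain or a chain ending in an amine or a carboxylic acid on this nitrogen would continue the same downward run remains open. On these data alone, it is also open whether the step from cyclobutylmethyl to cyclobutyl would be of similar size on the core of compound 2.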